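Swapping the aryl group on the hydrazone of compound 2

The source may hold more compounds than are shown below. What is called first, only, known or untested is meant among the compounds shown, and "the series" means these compounds.

Compound 2 `O=C(N/N=C/c1cccc(F)c1)c1cccnc1Nc1cccc(C(F)(F)F)c1` stands highest of the three measured compounds in a functional assay on the whole organism (strain Wistar) for inhibition, with Rattus norvegicus as the target, read by paw edema, with a stated time of 3 h, at a dose of 10 mg/kg by the intraperitoneal route (on this read-out higher numbers stand for more inhibition at the one dose given (going by the name of the read-out) and lower numbers for less inhibition), where compound 2 gives 37%. Compound 1 `O=C(N/N=C/c1ccccc1)c1cccnc1Nc1cccc(C(F)(F)F)c1` gives 21.2%, and compound 3 `COc1ccc(/C=N/NC(=O)c2cccnc2Nc2cccc(C(F)(F)F)c2)c(OC)c1` gives 24.1%. The step of a number 15.8 percentage points higher from compound 1 to compound 2 (beyond the scatter) came with fluoro in place of hydrogen on an aromatic carbon, while the step of a number 2.9 percentage points higher from compound 1 to compound 3 (within the scatter) came with 2,4-dimethoxyphenyl in place of phenyl on a carbon with a double bond to nitrogen.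

Compound 4 `COc1ccc(/C=N/NC(=O)c2cccnc2Nc2cccc(C(F)(F)F)c2)cc1OC` differs from compound 2 by 3,4-dimethoxyphenyl in place of 3-fluorophenyl on a carbon with a double bond to nitrogen. The step that bears on it most directly is a number 12.9 percentage points lower from compound 2 to compound 3 (beyond the scatter), where 2,4-dimethoxyphenyl replaced 3-fluorophenyl on a carbon with a double bond to nitrogen. Compound 4 carries 3,4-dimethoxyphenyl rather than 2,4-dimethoxyphenyl, and on the strength of that single comparison a change of like size and direction is expected, with a wide spread. Compound 4 is therefore expected to give 25% in this assay, with a range from 14% to 37%. That expectation is estimated to mean a step of a number 12 percentage points lower from compound 2 to compound 4 (beyond the scatter).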

Compound 4, a percentage reported as inhibition, in the whole organism at one dose (the size of the read-out at that dose, not a potency): 44%
Beside the measured number, compound 4's estimate is 19 percentage points below it; measured number above the stated range.
By their numbers in this assay, from the lowest: compounds 1 and 3 (each within the scatter of the next); then compounds 2 and 4 (each within the scatter of the next).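

In this assay, the two dimethoxyphenyl isomers are not interchangeable on a carbon with a double bond to nitrogen: 3,4-dimethoxyphenyl in place of 2,4-dimethoxyphenyl gives a number 19.9 percentage points higher from compound 3 to compound 4 (beyond the scatter) and so the arrangement of the methoxy groups matters, not merely their presence. Fluoro is also not the only substitution that lifts the number over plain phenyl, since the dimethoxy pattern gives a number 22.8 percentage points higher from compound 1 to compound 4 (beyond the scatter) while the direct exchange of 3-fluorophenyl reads a number 7 percentage points higher from compound 2 to compound 4 (within the scatter) and leaves those two groups unseparated. Nothing available here accounts for these differences.

On these data alone, it remains open whether both methoxy groups are needed, or whether a single methoxy group, a hydroxyl or an amine on the phenyl ring would serve as well. As far as these compounds go, it is also open whether compound 2 and compound 4 would stay level at other doses.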